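Dropping One Chloro Group from a Weakly Cytotoxic Pair

The compounds below may be only part of what the source reports. "The series", "measured", "known", "first", "only" and "open" are said of these compounds alone.

Two compounds with a shared core have been run in a functional assay on RPMI-8226 cells (Homo sapiens) for cytotoxicity, read by sulforhodamine B assay, with a stated time of 48 h; a lower number here means that less compound is tolerated, a higher number that more compound is tolerated. Compound 1 `ClCc1ccc(Cn2cnc3c(Cl)ncnc32)cc1` carries a single chloro group on its core. In this assay compound 1 gives > 100000 nM, which is a limit of the assay and not a number. Compound 2 `ClCc1ccc(Cn2cnc3nc(Cl)nc(Cl)c32)cc1` carries two chloro groups on the same core. In this assay, within the data shown here, compound 2 gives 97700 nM, and it stands as the only compound with an actual number among the two values shown. The remaining value sits at the limit of > 100000 nM in this assay, at which 1 of the 2 values shown sits.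

Compound 3 `ClCc1ccc(Cn2cnc3ncnc(Cl)c32)cc1` is the next compound to be measured. It differs from compound 2 in one place: hydrogen in place of chloro on an aromatic carbon. Among the measured compounds shown here, no step between two measured compounds that differ in one place is available to guide this change. The step from compound 2 to compound 3 in this assay is therefore expected to be small, in no particular direction, and within the scatter, as a 1.0-fold higher number from compound 2 to compound 3 (0.01 log units; within the scatter). Compound 3 is expected to give 100000 nM, with a range from 40000 nM to 250000 nM, and a fair chance that this assay reports only a limit.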

Compound 3, concentration lethal to 50% of the cells: 5620 nM
Beside the measured number, compound 3's estimate is 18-fold (1.25 log units) above it, outside the stated range (below it).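

The step shows that the aromatic carbon between two ring nitrogen atoms is not a silent position in this assay: with hydrogen in place of chloro there, the result is a 17-fold lower number from compound 2 to compound 3 (1.24 log units; beyond the scatter), so that compound 3 is tolerated at a much lower concentration than compound 2. Among these compounds, this is the first step that can be read as a number, and it shows that this single chloro group weighs heavily on the read-out, with the removal of the group moving the value towards less compound being tolerated, while the other chloro group on the core stays in place. Compound 1 gives a limit of the assay and not a number, so it supplies no step of its own: the limit of > 100000 nM in this assay, at which 1 of the 3 values shown sits.

Going by these compounds, what remains open is whether hydrogen is special at this position, or whether an amine, a methoxy group or a fluoro group on the same carbon would give a value closer to compound 3 or to compound 2. Also open, on these data alone, is whether a step of this size would hold if the remaining chloro group on the core were replaced by an amine, and the values offer no explanation for the step itself.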